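Working notes: methoxy in place of chloro

This account rests on a few compounds, and the source may have more. Where it says the series, first, only, none or still open, it means among the compounds named here.

Compound 1 (`C=CC(=O)Nc1nc(-c2ccccc2Cl)cs1`) gives 12300 nM
Compound 2 (`C=CC(=O)Nc1nc(-c2ccc(C(F)(F)F)cc2)cs1`) gives 4000 nM

Both numbers come from a functional assay on HCT-116 cells (Homo sapiens) for antiproliferative activity, read by MTT assay, with a stated time of 72 h (on this read-out lower numbers stand for stronger inhibition and higher numbers for weaker inhibition), and compound 1 stands highest of the two, with compound 2 lower by more than the usual scatter. Compound 3 (`C=CC(=O)Nc1nc(-c2ccccc2OC)cs1`) is not yet measured and has methoxy in place of chloro on an aromatic carbon relative to compound 1. Among the measured compounds shown here, no measured step sizes this change, so in this assay only a small move toward a lower number is expected, probably not beyond the scatter. The estimated 1.4-fold lower number from compound 1 to compound 3 (0.14 log units; within the scatter) is therefore modest. Compound 3 is estimated at 9000 nM with an expected range of 3500 nM to 25000 nM in this read-out.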

Compound 3, half-maximal inhibitory concentration: > 30000 nM
Compound 3 gave a limit, no number; the forecaster's own chance of this, stated with the estimate: 3%; middle value at least 3.3-fold (0.52 log units) from the limit.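

Among the compounds shown here, on an aromatic carbon ortho to a large group, methoxy in place of chloro gives the first measured change at this position, and it runs toward weaker inhibition: an at least 2.4-fold higher number from compound 1 to compound 3 (0.38 log units; beyond the scatter). The read-out at this position therefore depends on the group placed there, at least for these two groups. Compound 3 stands at a limit, not a number: the limit of > 30000 nM in this assay, at which 1 of the 3 values shown sits.

From the compounds shown here alone, the true size of the step stays open. So does whether an amine or a fluoro group at this same place would read nearer compound 1 or compound 3.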